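Ethoxy for difluoromethoxy in a non-cytotoxic series

A few compounds are considered here, and "the series" means these few. Any claim that something is new, unique, unknown or untested is made for them only; others in the source may bear on it.

Compound 1 `O=C(Nc1ccc(OC(F)F)cc1)c1cccc(/C=C2\CC(=O)N(c3ccccc3)C2=O)c1` was examined in an ADME assay on NCM460 cells (Homo sapiens) for cytotoxicity, read by MTT assay, with a stated time of 72 h; a higher number here means a weaker inhibitor, a lower number a stronger inhibitor. There compound 1 reaches only a limit of the assay, > 100000 nM. Compound 2 `CCCCNC(=O)c1cccc(/C=C2\CC(=O)N(Cc3ccccc3)C2=O)c1` likewise sits at a limit, > 100000 nM. Compound 3 `O=C(Nc1ccc(Cl)cc1)c1cccc(/C=C2\CC(=O)N(Cc3ccccc3)C2=O)c1` also gives only a limit, > 100000 nM. Among the measured compounds shown here, the single step between measured compounds, a step that the two limits leave unreadable from compound 2 to compound 3, has both ends at limits and cannot be sized. Every measured value shares (the limit of > 100000 nM in this assay, at which 3 of the 3 values shown sit). Compound 4 `CCOc1ccc(NC(=O)c2cccc(/C=C3\CC(=O)N(c4ccccc4)C3=O)c2)cc1` differs from compound 1 by ethyl in place of difluoromethyl on an oxygen on an aromatic ring. For the measured compounds named here, no measured step bears directly on this change, and the three limits give no direction to expect. Compound 4 is therefore expected to remain at the limit as well, with an estimated step that the limit leaves unreadable from compound 1 to compound 4. The estimated value of compound 4 is 150000 nM, in a range from 50000 nM to 500000 nM.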

Compound 4, half-maximal inhibitory concentration: > 100000 nM
Compound 4 ended at the assay's limit; the forecaster's own chance of this, stated with the estimate: 85%; the middle value does not contradict the limit.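

No step can be read from compound 1 to compound 4 in this assay for the change from difluoromethoxy to ethoxy. The compounds shown leave open how far each lies past the one limit they all share: the limit of > 100000 nM in this assay, at which 4 of the 4 values shown sit.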